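Swapping the Sulfonyl Ring in a Weakly Cytotoxic Series

This account rests on a few compounds, and the source may have more. Where it says the series, first, only, none or still open, it means among the compounds named here.

Measured compounds:
- Compound 1, `Cc1noc(C)c1S(=O)(=O)N1CCC(N2CCC(C)CC2)CC1`; in an ADME assay on HCT-116 cells (Homo sapiens) for cytotoxicity, read by CellTiter-Glo, with a stated time of 72 h (a higher number here means a weaker inhibitor, a lower number a stronger inhibitor), compound 1 gives > 10000 nM.
- Compound 2, `Cc1cc(C)c(S(=O)(=O)N2CCC(N3CCC(CCO)CC3)CC2)c(C)c1`; in this assay compound 2 gives > 5000 nM.
- Compound 3, `CC1CCCN(C2CCN(S(=O)(=O)c3ccc(OC(F)F)cc3)CC2)C1`; in this assay compound 3 gives > 5000 nM.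

None of these three values is a number; each is a limit of this assay, meaning the compound showed too little cytotoxicity for the assay to resolve a value. Compound 1 sits at the limit of > 10000 nM in this assay, at which 1 of the 3 values shown sits. Compounds 2 and 3 sit at the limit of > 5000 nM in this assay, at which 2 of the 3 values shown sit. So compound 1 stands simply among compounds that did not register a measurable effect, and no ordering among the three can be drawn.

Compound 4, `CC1CCN(C2CCN(S(=O)(=O)c3ccc(Cl)cc3Cl)CC2)CC1`, has not yet been measured. It differs from compound 1 at the sulfonyl sulfur: 2,4-dichlorophenyl in place of 3,5-dimethyl-1,2-oxazol-4-yl on a sulfonyl sulfur

Within the data shown here, with every measured value a limit, there is no step between two known numbers to guide expectation. The shared core is kept, and all three measured variations of the sulfonyl ring gave limits, so in this assay the expected step from compound 1 to compound 4 is none beyond the usual scatter, most likely another limit.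

The estimate for compound 4 in this assay is 15000 nM, with a range from 4000 nM to 60000 nM. This estimate corresponds to an expected step that the limit leaves unreadable from compound 1 to compound 4.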

Compound 4, half-maximal inhibitory concentration: > 5000 nM
Compound 4 gave a limit, no number; the forecaster's own chance of this, stated with the estimate: 80%; the middle value does not contradict the limit.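

Among these compounds, compound 1 and compound 4 both give limits rather than numbers in this assay, so no step between them can be read, and the effect of placing 2,4-dichlorophenyl where 3,5-dimethyl-1,2-oxazol-4-yl stood stays unknown. The compounds shown leave open whether any change to the sulfonyl ring can produce a measurable value here.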